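Methoxy in Place of Trifluoromethyl: What Compound 4 Might Give

The compounds below may be only part of what the source reports. "The series", "measured", "known", "first", "only" and "open" are said of these compounds alone.

Three compounds have been measured in a functional assay on MCF7 cells (Homo sapiens) for antiproliferative activity, read by MTT assay, with a stated time of 48 h; a lower number here means a stronger inhibitor, a higher number a weaker inhibitor:
compound 1 `O=C(/C=C/c1ccc(Cl)cc1)Nc1cc(-c2ccc(Br)cc2)[nH]n1` gives 770 nM
compound 2 `Cc1ccc(-c2cc(NC(=O)/C=C/c3ccc(C(F)(F)F)cc3)n[nH]2)cc1` gives 720 nM
compound 3 `O=C(/C=C/c1ccc(Cl)cc1)Nc1cc(-c2ccccc2)[nH]n1` gives 970 nM

Compound 2 sits at the low end of these three numbers, but its distance to compound 1 and its distance to compound 3 both lie within the scatter, so the three compounds are not separated from one another. For the measured compounds named here, the only step between compounds that differ in one place runs from compound 1 to compound 3, hydrogen in place of bromo on an aromatic carbon, and it gave a 1.3-fold higher number from compound 1 to compound 3 (0.10 log units; within the scatter).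

Compound 4 `COc1ccc(/C=C/C(=O)Nc2cc(-c3ccc(C)cc3)[nH]n2)cc1` has not been measured. It differs from compound 2 by methoxy in place of trifluoromethyl on an aromatic carbon. Going by the values given here, no measured pair exchanges a trifluoromethyl or introduces a methoxy, so the step from compound 1 to compound 3 bears on it only as an example: a single swap of a group on that ring left the number within the scatter. No step beyond the scatter is therefore expected in this assay. Compound 4 is expected to give 800 nM, between 400 nM and 1600 nM. The step implied, a 1.1-fold higher number from compound 2 to compound 4 (0.05 log units; within the scatter), is expected to stay within the scatter.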

Compound 4, half-maximal inhibitory concentration: 860 nM
The estimate for compound 4 lay 1.1-fold (0.03 log units) below the measured number; low and high end bracket the measured number.
By their numbers in this assay, from the lowest: compounds 2, 1, 4 and 3 (each within the scatter of the next).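

Methoxy in place of trifluoromethyl on an aromatic carbon, para to a large group, gave in this assay a 1.2-fold higher number from compound 2 to compound 4 (0.08 log units; within the scatter), so a second ring of the shared core, not the one that lost bromo in the earlier step, has now been probed by a single exchange. At this position, methoxy brings one hydrogen-bond acceptor where trifluoromethyl has none, and that difference came with a step that stays within the scatter. No measurement is available that would account for this result.

Neither step shown lies beyond the scatter, so it remains open what kind of group, if any, would separate compounds at this position. An amine, a carboxylic acid or a longer alkoxy chain in place of methoxy would test this.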